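Swapping Methoxy for Trifluoromethyl on the Aromatic Ring

This account rests on a few compounds, and the source may have more. Where it says the series, first, only, none or still open, it means among the compounds named here.

Among the compounds with values here, in an ADME assay on the whole organism (strain Sprague-Dawley) for pharmacokinetics, with Rattus norvegicus as the target, using cassette dosing, at a dose of 1 mg/kg by the oral route (on this read-out higher numbers stand for higher oral bioavailability and lower numbers for lower oral bioavailability), compound 1 `O[C@]1(Cc2cc(-c3cn[nH]c3)on2)CC[C@H](Cc2ccccc2)CC1` gives 46.3%, while compound 2 `COc1ccc(C[C@H]2CC[C@](O)(Cc3cc(-c4cn[nH]c4)on3)CC2)cc1` gives 23.7%, the lower of the two numbers so far. Within the data shown here, the only measured step, a number 22.6 percentage points lower from compound 1 to compound 2 (beyond the scatter), lies beyond the usual scatter and comes with methoxy in place of hydrogen on an aromatic carbon.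

Compound 3 `O[C@]1(Cc2cc(-c3cn[nH]c3)on2)CC[C@H](Cc2ccc(C(F)(F)F)cc2)CC1` has not yet been measured. It differs from compound 2 in one group: trifluoromethyl in place of methoxy on an aromatic carbon. This is trifluoromethyl in place of methoxy on an aromatic carbon, para to a large group.

Among the measured compounds shown here, that single step is the only guide, and it is a rough one, since no measured compound carries trifluoromethyl. Still, compound 1, which has no methoxy, stands higher at 46.3%, so removing methoxy may recover part of that gap. The expected change is a modest rise: a number 11.3 percentage points higher from compound 2 to compound 3 (beyond the scatter). For compound 3, the estimated value is 35%, with an expected range from 15% to 55%.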

Compound 3, oral bioavailability: 67.5%
Compound 3: the middle estimate sits 32.5 percentage points below what was measured; the whole stated range lies below it.
By their numbers in this assay, from the lowest: compound 2; then compound 1; then compound 3.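

This result shows that a group on this aromatic carbon, para to a large group, does not have to lower the reading in this assay: with trifluoromethyl in place of hydrogen, the result is a number 21.2 percentage points higher from compound 1 to compound 3 (beyond the scatter), whereas methoxy in place of hydrogen gave a number 22.6 percentage points lower from compound 1 to compound 2 (beyond the scatter). The direct exchange of methoxy for trifluoromethyl at this same place gives a number 43.8 percentage points higher from compound 2 to compound 3 (beyond the scatter), so the two groups move the read-out in opposite directions from the unsubstituted compound, and the identity of the group matters more here than the mere presence of one. The information at hand offers no explanation for why these two groups differ so sharply in the whole animal.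

With only hydrogen, methoxy and trifluoromethyl shown at this place, these three compounds cannot establish a wider trend, and a single chlorine atom, a nitrile or an amine could each fall anywhere relative to them. From the compounds shown here alone, it also remains open whether trifluoromethyl would give a similar rise on a different core, since all three compounds share the same one.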